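Swapping nitro for hydrogen at the assay limit

A few compounds are considered here, and "the series" means these few. Any claim that something is new, unique, unknown or untested is made for them only; others in the source may bear on it.

- Compound 1 `C[C@@H](/N=C(\S)NCc1ccc(C(C)(C)C)cc1)c1ccccc1`: > 100000 nM (a limit)
- Compound 2 `C[C@H](/N=C(\S)NCc1ccc(C(C)(C)C)cc1)c1ccc([N+](=O)[O-])cc1`: > 100000 nM (a limit)

In a functional assay with Rattus norvegicus as the target (a higher number here means that more compound is needed for the effect, a lower number that less compound is needed), compound 2 gives > 100000 nM, which is a limit of the assay and not a number. Compound 1 also gives only a limit, > 100000 nM. The evidence so far is therefore thin: the limit of > 100000 nM in this assay, at which 2 of the 2 values shown sit.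

Compound 3 `C[C@H](/N=C(\S)NCc1ccc(C(C)(C)C)cc1)c1ccccc1` has hydrogen in place of nitro on an aromatic carbon. Among the measured compounds shown here, no measured step shows the size of this change. No step beyond the scatter is expected in this assay, and another limit is the likeliest result. Compound 3 is estimated at 100000 nM, with an expected range from 30000 nM to 300000 nM.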

Compound 3, half-maximal effective concentration: > 100000 nM
Compound 3: a limit, no number (the forecaster's own chance of this, stated with the estimate: 85%); the middle value lies on the limit itself.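

No step can be read from compound 3 to compound 1 or compound 2, since all three give only a limit and no number: the limit of > 100000 nM in this assay, at which 3 of the 3 values shown sit.

From the compounds shown here alone, whether nitro or the configuration as drawn makes any difference in this assay stays open.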